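Notes on the carbonyl substituent of the shared core

A few compounds are considered here, and "the series" means these few. Any claim that something is new, unique, unknown or untested is made for them only; others in the source may bear on it.

Measured so far:
compound 1 `Cc1cc(/C=C/C#N)cc(C)c1Oc1cc(Nc2ccc(C#N)cc2)c(N)cc1C(=O)NCCCO`: 3.22
compound 2 `Cc1cc(/C=C/C#N)cc(C)c1Oc1cc(Nc2ccc(C#N)cc2)c(N)cc1C(=O)N1CC1`: 2.21

Among the measured compounds shown here, compound 2 holds the lowest of the two numbers in a physicochemical assay for lipophilicity, read by HPLC, measured as octanol-water partition, with a stated time of 24 h, at pH 7.4; a higher number here means a more lipophilic compound, a lower number a more polar compound; its only neighbour is compound 1, and the single measured step, a number 1.01 log units lower from compound 1 to compound 2 (beyond the scatter), separates them. For the measured compounds named here, that step is large and beyond the scatter, and it is the only measured change at the carbonyl carbon of the core.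

Compound 3 `Cc1cc(/C=C/C#N)cc(C)c1Oc1cc(Nc2ccc(C#N)cc2)c(N)cc1C(=O)OCCC#N` differs from compound 2 in the same place: 2-cyanoethoxy in place of aziridin-1-yl on a carbonyl carbon. Going by the values given here, the step from compound 1 to compound 2 bears on it only as a measure of how much the group on this carbonyl carbon can move the read-out; it exchanges one nitrogen-linked group for another and gives no direct precedent for an oxygen-linked group, so its direction cannot simply be carried over. The aziridin-1-yl group that enters in that step now leaves again, and the 2-cyanoethoxy group that enters is larger by the count given.

On this basis a rise of a number 0.69 log units higher from compound 2 to compound 3 (beyond the scatter) is expected for compound 3, with compound 3 estimated at 2.9, in the range 2.3 to 3.5.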

Compound 3, partition coefficient: > 5
Compound 3: a limit, no number; the forecaster's own chance of this, stated with the estimate: 0%; middle value at least 2.10 log units away from the limit.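

Compound 3 gives > 5 in this assay, which is a limit of the assay and not a number: the limit of > 5 in this assay, at which 1 of the 3 values shown sits.

Read as bounds, the change to 2-cyanoethoxy gives a number at least 2.79 log units higher from compound 2 to compound 3 (beyond the scatter) where it replaces aziridin-1-yl, and a number at least 1.78 log units higher from compound 1 to compound 3 (beyond the scatter) where it replaces (3-hydroxypropyl)amino. The group on this carbonyl carbon therefore spans a wider range of the read-out than a number 1.01 log units lower from compound 1 to compound 2 (beyond the scatter) alone showed, and among these three compounds the single oxygen-linked group stands above both nitrogen-linked groups, with no compound going against this.

Going by these compounds, the size of either new step beyond its bound stays unknown, and compound 3 alone cannot separate the oxygen link on the carbonyl carbon from the nitrile at the end of the 2-cyanoethoxy chain. On these data alone, a plain ethoxy group would bear on that separation, and how it or a 2-cyanoethylamino group on the same carbonyl carbon would read remains open.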